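The compounds below may be only part of what the source reports. "The series", "measured", "known", "first", "only" and "open" are said of these compounds alone.

Among the compounds with values here, in a functional assay on A549 cells (Homo sapiens) for antiproliferative activity, read by sulforhodamine B assay, with a stated time of 3 days (a lower number here means that less compound is needed, a higher number that more compound is needed for the effect), compound 1 (`CCCC1=C(OC)C(CCC)(CCC)C(=O)/C(=C(O)\C=C\c2ccccc2)C1=O`) gives 3.6 uM and so holds the higher of the two numbers measured so far. Compound 2 (`CCCC1=C(OC)C(CCC)(CCC)C(=O)/C(=C(O)\C=C\c2ccc(I)cc2)C1=O`) gives 1.4 uM with iodo in place of hydrogen on an aromatic carbon. Compound 3 (`CCCC1=C(OCC(C)C)C(CCC)(CCC)C(=O)/C(=C(O)\C=C\c2ccccc2)C1=O`) changes another place, where methoxy becomes isobutoxy (isopropyl in place of hydrogen on a saturated chain carbon bound to an oxygen on an unsaturated carbon). Within the data shown here, no measured compound alters that group, so the step to compound 2 (a 2.6-fold lower number from compound 1 to compound 2 (0.41 log units; beyond the scatter)) bears on it only indirectly, as a guide to size. On that basis a modest move towards a lower number is expected in this assay though a result within the scatter remains possible. The expected change is a 2.1-fold lower number from compound 1 to compound 3 (0.33 log units; beyond the scatter) in this estimate. For compound 3 the estimated value is 1.7 uM within an expected range of 0.7 uM to 4.5 uM for the coming measurement.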

Compound 3, concentration for half-maximal effect: 1.7 uM
Beside the measured number, compound 3's estimate shows no gap at the digits printed; low and high end bracket the measured number.
By their numbers in this assay, from the lowest: compounds 2 and 3 (each within the scatter of the next); then compound 1.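

In this assay, the step of a 2.1-fold lower number from compound 1 to compound 3 (0.33 log units; beyond the scatter) shows that the methoxy group is not fixed: with isopropyl in place of hydrogen on a saturated chain carbon bound to an oxygen on an unsaturated carbon, giving isobutoxy, the number falls modestly. Within the data shown here, the earlier compounds had changed only an aromatic carbon, so this is the first reading at this second place on the shared core, and it shows that a change here can also shift the number beyond the scatter. Nothing available explains this step.

Going by these compounds, it remains open whether a longer chain such as hexyloxy, a benzyloxy group or an aminoethoxy group on this oxygen would move the number further, or in the opposite direction. On these data alone, it is also open whether the iodo and isobutoxy changes would add up in a single compound.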